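Exposure notes: the difluorophenyl variant of the shared core

The source may hold more compounds than are shown below. What is called first, only, known or untested is meant among the compounds shown, and "the series" means these compounds.

Among the compounds with values here, compound 3 `O=C(Nc1ccc(F)c(-c2nc3ncc(-c4ccc(F)cc4)cc3[nH]2)c1)N1CCCC1` gives 6270 nM in an ADME assay on the whole organism (Mus musculus, strain Swiss Webster) for pharmacokinetics, read by LC-MS, at a dose of 50 mg/kg by the oral route (on this read-out lower numbers stand for lower exposure and higher numbers for higher exposure at the dose given), the lowest of the three numbers so far. Compound 1 `O=C(Nc1ccc(F)c(-c2nc3ncc(-c4cccc(F)c4)cc3[nH]2)c1)N1CCCC1` gives 7000 nM, and a 1.1-fold lower number from compound 1 to compound 3 (0.05 log units; within the scatter), so these two cannot be ordered. Within the data shown here, compound 2 `O=C(Nc1ccc(F)c(-c2nc3ncc(-c4cccnc4F)cc3[nH]2)c1)N1CCCC1` gives 25600 nM; a 4.1-fold lower number from compound 2 to compound 3 (0.61 log units; beyond the scatter) and a 3.7-fold higher number from compound 1 to compound 2 (0.56 log units; beyond the scatter), so compound 2 is the only member set apart from compound 3 beyond the scatter.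

Compound 4 `O=C(Nc1ccc(F)c(-c2nc3ncc(-c4cccc(F)c4F)cc3[nH]2)c1)N1CCCC1` is the next member: 2,3-difluorophenyl in place of 4-fluorophenyl on an aromatic carbon. The measured step most like this change is a 1.1-fold lower number from compound 1 to compound 3 (0.05 log units; within the scatter), also an exchange of one fluorophenyl for another on the same aromatic carbon, and it stayed within the scatter. The steps of a 3.7-fold higher number from compound 1 to compound 2 (0.56 log units; beyond the scatter) and a 4.1-fold lower number from compound 2 to compound 3 (0.61 log units; beyond the scatter) do move beyond the scatter, but each involves 2-fluoropyridin-3-yl, which compound 4 does not. Among the measured compounds shown here, the 2,3-difluorophenyl group itself has no counterpart among the measured compounds. In this assay the expectation for compound 4 is therefore a 1.1-fold higher number from compound 3 to compound 4 (0.05 log units; within the scatter), no step beyond the scatter. Compound 4 is estimated at 7000 nM, in the range 3000 nM to 16000 nM.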

Compound 4, maximal plasma concentration: 1830 nM
Estimate against measurement, compound 4: 3.8-fold (0.58 log units) above; measured number outside the range, below it.
By their numbers in this assay, from the lowest: compound 4; then compounds 3 and 1 (each within the scatter of the next); then compound 2.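

In this assay, the earlier exchange of one fluorophenyl group for another on this aromatic carbon stayed within the scatter, which made the position look indifferent to the choice of fluorophenyl group. The 2,3-difluorophenyl group ends that reading, with a 3.4-fold lower number from compound 3 to compound 4 (0.53 log units; beyond the scatter), and fluoro in place of hydrogen on the 3-fluorophenyl ring gives a 3.8-fold lower number from compound 1 to compound 4 (0.58 log units; beyond the scatter), so a single added fluoro on this ring is enough to move the number beyond the scatter. The widest step in the series now separates the two groups at the ends of the range, a 14-fold lower number from compound 2 to compound 4 (1.15 log units; beyond the scatter), which shows that with the shared core held constant this one position spans a large part of the read-out, though nothing at hand gives a reason for these differences.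

The compounds shown leave open whether the lower number goes with a second fluoro as such or with this particular pattern, a question that 2,4-difluorophenyl or 3,4-difluorophenyl would address. On these data alone, it is also open how the number responds to other groups on this ring, such as chloro, methoxy or an amine, or to a pyridin-3-yl group without fluoro.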